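The source may hold more compounds than are shown below. What is called first, only, known or untested is meant among the compounds shown, and "the series" means these compounds.

Working notes on the series. Of the compounds shown here, three have been measured in an assay on isolated protein for inhibition of vascular endothelial growth factor receptor 1 (Homo sapiens), read by HTRF, tested at 10 uM; a higher number here means more inhibition at the concentration tested (going by the name of the read-out), a lower number less inhibition. Compound 1 `COC[C@@H]1CCCN1C(=O)[C@@H]1CCCN1c1nccc(Nc2ccccc2)n1` gives 1%; compound 2 `Clc1ccc2sc(CN3CCN(c4ncnc5c4CN(Cc4ccccc4)CC5)CC3)cc2c1` gives 0%; compound 3 `Cc1cccc(Nc2nccc3c2CN(C(=O)c2cc(C)n(C)c2C)CC3)c1` gives 0%. Compound 2 is level with compound 3 at the digits reported, the two together the lowest of the three numbers, and the number for compound 1 sits only a little higher, within the scatter, so the whole set reads as essentially inactive at the concentration tested. Compound 4 `O=C(CN1CCN(c2ncnc3c2CN(Cc2ccccc2)CC3)CC1)Nc1cc(F)ccc1F` is not yet measured. It differs from compound 2 in one place: (2,5-difluorophenyl)carbamoyl in place of 5-chloro-1-benzothiophen-2-yl on a saturated chain carbon bound to an amine nitrogen in a ring. For the measured compounds named here, no comparable step is available among the measured compounds, so the change can only be weighed against the flat background of the three numbers. The expected step in this assay is none beyond the scatter, a number 2 percentage points higher from compound 2 to compound 4 (within the scatter). For compound 4 the estimate is 2%, within a range from -6% to 12%.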

Compound 4, a percentage reported as inhibition, at one concentration (the size of the read-out at that concentration, not a potency): 0%
The estimate for compound 4 lay 2 percentage points above the measured number, within the range that was stated.
By their numbers in this assay, from the lowest: compounds 2, 3, 4 and 1 (each within the scatter of the next).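

In this assay, for the compounds shown here, the exchange of 5-chloro-1-benzothiophen-2-yl for (2,5-difluorophenyl)carbamoyl on a saturated chain carbon bound to an amine nitrogen in a ring gives no change at the digits printed from compound 2 to compound 4 (within the scatter) and is the first step that can be read. At the concentration tested, this position therefore shows no response to this change, although the two groups differ in ring content and in hydrogen-bond donors. Nothing measured explains this result.

With both numbers so low, the step says little about this position in a compound showing clear inhibition. Going by these compounds, whether a carboxylic acid or a primary amine here would raise the number remains open.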